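Chloro and fluoro substituents on a spiro-indolinone piperazine series

The source may hold more compounds than are shown below. What is called first, only, known or untested is meant among the compounds shown, and "the series" means these compounds.

Compound 1 `CCC1(CCCCN2CCN(c3cccc(Cl)c3)CC2)C(=O)Nc2ccccc21`: 0.41 nM
Compound 2 `CCC1(CCCCN2CCN(c3ccc(Cl)c(Cl)c3)CC2)C(=O)Nc2ccccc21`: 0.63 nM
Compound 3 `CCC1(CCCCN2CCN(c3cccc(Cl)c3)CC2)C(=O)Nc2cc(F)ccc21`: 0.67 nM

Of the compounds shown here, three have been measured in an assay on CHO cells for displacement of a labelled ligand from 5-hydroxytryptamine receptor 7 (Homo sapiens); on this read-out higher numbers stand for weaker inhibition and lower numbers for stronger inhibition. Compound 1 gives 0.41 nM. Compound 2 differs from compound 1 by chloro in place of hydrogen on an aromatic carbon. Compound 2 gives 0.63 nM, a step of a 1.5-fold higher number from compound 1 to compound 2 (0.19 log units; within the scatter). Compound 3 differs from compound 1 by fluoro in place of hydrogen on an aromatic carbon. Compound 3 gives 0.67 nM, a step of a 1.6-fold higher number from compound 1 to compound 3 (0.21 log units; within the scatter). Compound 3 and compound 2 have not been compared directly; their two values lie close together.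

Compound 4 `CCC1(CCCCN2CCN(c3cccc(Cl)c3)CC2)C(=O)Nc2cc(F)c(Cl)cc21` has not yet been measured. It differs from compound 3 by chloro in place of hydrogen on an aromatic carbon. This is the same kind of change as that from compound 1 to compound 2, and it occurs twice among these compounds, but the places are not the same: in compound 2 the entering chloro sits ortho to a chloro group and para to a large group, whereas in compound 4 it sits on a ring that is part of a fused or bridged system of two rings, ortho to a fluoro group, meta to a fused ring and para to a fused ring. The earlier step, a 1.5-fold higher number from compound 1 to compound 2 (0.19 log units; within the scatter), stayed within the scatter. For compound 4 a step of about a 1.5-fold higher number from compound 3 to compound 4 (0.17 log units; within the scatter) is therefore expected in this assay, resting on that earlier step and on the value of compound 3, 0.67 nM, while allowing for the different surroundings. The estimate for compound 4 is 1 nM, with a likely range from 0.4 nM to 2.5 nM.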

Compound 4, inhibition constant: 9.07 nM
Beside the measured number, compound 4's estimate is 9.1-fold (0.96 log units) below it; measured number above the stated range.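

In this assay, chloro in place of hydrogen brought a 14-fold higher number from compound 3 to compound 4 (1.13 log units; beyond the scatter), a large step, whereas the same kind of change had stayed within the scatter on the core of compound 1. Set side by side, the two steps do not agree, so in this series the size of this change did not carry over from one core to the other: the same change on two cores in this assay, a 1.5-fold higher number (0.19 log units; within the scatter) from compound 1 to compound 2 and a 14-fold higher number (1.13 log units; beyond the scatter) from compound 3 to compound 4, 8.8-fold (0.94 log units) apart, beyond the scatter of two such steps This does not show what lies behind the gap, as the two chloro groups enter at different places, with the one in compound 4 sitting on the fused ring system, ortho to a fluoro group, and a single pair of steps cannot separate the place on the ring from the presence of that fluoro group.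

The compounds shown leave open whether a chloro at this place would bring a step of similar size with hydrogen in place of the fluoro group. They also leave open whether a smaller or larger group at the same place, such as a methyl or a methoxy group, would bring a step of the same size as the chloro.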